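A few compounds are considered here, and "the series" means these few. Any claim that something is new, unique, unknown or untested is made for them only; others in the source may bear on it.

Of the compounds shown here, three that share one core have so far been tested in a functional assay on HEK293 cells for positive allosteric modulation of metabotropic glutamate receptor 5 (Homo sapiens), read by FLIPR and calcium flux; on this read-out higher numbers stand for an effect only at larger amounts of compound and lower numbers for an effect already at smaller amounts. Compound 1 `O=C1c2ccc(C#Cc3ccccc3)nc2CCN1C1CCCC1` gives 5.9 nM. Compound 2 `O=C1c2ccc(C#Cc3cccnc3)nc2CCN1C1CCCC1`, in which a pyridin-3-yl takes the place of the phenyl, gives 748 nM; this is the step of a 130-fold higher number from compound 1 to compound 2 (2.10 log units; beyond the scatter). Compound 3 `O=C1c2ccc(C#Cc3ccccc3)nc2CCN1C1CCCCC1`, in which a cyclohexyl takes the place of the cyclopentyl on the amide-type nitrogen in a ring, gives 40 nM, the second highest of the three numbers; the step of a 6.8-fold higher number from compound 1 to compound 3 (0.83 log units; beyond the scatter) is modest.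

Compound 4 `Cc1ccccc1C#Cc1ccc2c(n1)CCN(C1CCCCC1)C2=O` has not yet been measured. It differs from compound 3 by methyl in place of hydrogen on an aromatic carbon. Of the two measured steps, one swaps the whole ring attached to the triple bond and the other swaps the ring on the nitrogen; neither adds a small group to the phenyl, so neither bears directly on this change. The large jump a 130-fold higher number from compound 1 to compound 2 (2.10 log units; beyond the scatter) shows that the ring on the triple bond matters a great deal, but a methyl is a far smaller alteration than a ring nitrogen. With nothing pointing clearly either way, the expected step of a 1.1-fold lower number from compound 3 to compound 4 (0.06 log units; within the scatter) is small, within the usual scatter. Compound 4 is therefore estimated at 35 nM, with a range from 9 nM to 140 nM.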

Compound 4, half-maximal effective concentration: 466 nM
Compound 4: middle estimate off by 13-fold (1.12 log units), on the low side; the measured number lies above the stated range.
By their numbers in this assay, from the lowest: compound 1; then compound 3; then compounds 4 and 2 (each within the scatter of the next).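

In this assay, the methyl on the phenyl ring, ortho to a large group, gives a 12-fold higher number from compound 3 to compound 4 (1.07 log units; beyond the scatter), so the change from phenyl to 2-methylphenyl is a large step and not a minor adjustment. The earlier compounds shown here showed that replacing the whole phenyl ring with pyridin-3-yl could shift the number strongly, but they did not show that this ring is also sensitive to the addition of a single carbon, with no hydrogen-bond donor or acceptor and no net charge entering. No measurement available here explains why this one methyl has so large an effect.

The compounds shown leave open whether the same step would appear on the cyclopentyl compound 1, since the methyl has been seen only with cyclohexyl on the nitrogen. They also leave open how a fluorine, a chlorine or a methoxy group would behave at this same place, and whether a methyl elsewhere on the phenyl ring would give a step of similar size.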